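The source may hold more compounds than are shown below. What is called first, only, known or untested is meant among the compounds shown, and "the series" means these compounds.

Compound 1 `O=C(Nc1ccc(Oc2ccnc3[nH]ccc23)cc1)c1cn(-c2ccc(Br)cc2)c2ccccc2c1=O` and compound 2 `O=C(Nc1ccc(Oc2ccnc3[nH]ccc23)cc1)c1cn(-c2ccc(F)c(Cl)c2)c2ccccc2c1=O` share a core and differ only in the ring carried on the aromatic nitrogen. In a functional assay on A549 cells (Homo sapiens) for inhibition, read by MTT assay, with a stated time of 72 h (a higher number here means a weaker inhibitor, a lower number a stronger inhibitor), compound 1 gives 450 nM, and compound 2 gives 4810 nM, the higher of the two numbers measured; the step of an 11-fold higher number from compound 1 to compound 2 (1.03 log units; beyond the scatter) separates them. Compound 3 `O=C(Nc1ccc(Oc2ccnc3[nH]ccc23)c(F)c1)c1cn(-c2ccc(F)c(Cl)c2)c2ccccc2c1=O` keeps the ring of compound 2 on that nitrogen and changes a different place: fluoro in place of hydrogen on an aromatic carbon, ortho to a large group and meta to a large group. Among the measured compounds shown here, no measured step touches this position; the one known step, an 11-fold higher number from compound 1 to compound 2 (1.03 log units; beyond the scatter), concerns the other aromatic ring and so offers no guide to the size or direction of this change. The expectation for compound 3 is therefore a step of a 1.0-fold lower number from compound 2 to compound 3 (0.00 log units; within the scatter) of no size beyond the scatter. Compound 3 is estimated at 4800 nM in this assay, with a range from 1500 nM to 15000 nM.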

Compound 3, half-maximal inhibitory concentration: 2150 nM
Beside the measured number, compound 3's estimate is 2.2-fold (0.35 log units) above it; the range from low to high includes it.
By their numbers in this assay, from the lowest: compound 1; then compound 3; then compound 2.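

Among the compounds shown here, this position, on an aromatic carbon ortho to a large group and meta to a large group, is the first place outside the ring on the aromatic nitrogen where a change is seen to matter: in this assay there is a 2.2-fold lower number from compound 2 to compound 3 (0.35 log units; beyond the scatter), a modest step but one beyond the usual scatter. A single fluorine atom here is therefore tolerated and moves the number towards stronger inhibition, at least with the 3-chloro-4-fluorophenyl ring kept on the nitrogen. Nothing available explains why this step occurs.

On these data alone, whether a chloro, methyl or methoxy group at the same position would move the number the same way remains open. Also open, as far as these compounds go, is whether fluoro would give a similar step with the 4-bromophenyl ring of compound 1 on the nitrogen.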